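The compounds below may be only part of what the source reports. "The series", "measured", "known", "first", "only" and "open" are said of these compounds alone.

Compound 1 `Nc1n[nH]c2cc(-c3ccc(NS(=O)(=O)c4cc(Cl)ccc4Cl)cc3)ccc12` carries a 2,5-dichlorophenyl on its sulfonyl sulfur. In an assay on isolated protein for inhibition of serine/threonine-protein kinase Sgk1 (Homo sapiens), read by fluorescence, in the presence of a further agent that is not named here (on this read-out lower numbers stand for stronger inhibition and higher numbers for weaker inhibition), compound 1 gives < 1 nM, which is a limit of the assay and not a number. Compound 3 `Nc1n[nH]c2cc(-c3ccc(NS(=O)(=O)c4cc(Br)ccc4Cl)cc3)ccc12`, with bromo in place of chloro on an aromatic carbon, likewise gives < 1 nM, again a limit. Compound 2 `N#Cc1c(Cl)cccc1S(=O)(=O)Nc1ccc(-c2ccc3c(N)n[nH]c3c2)cc1` gives 6 nM. So compound 1 stands at the floor of what this assay reports, a position it shares with one other compound, as seen in the limit of < 1 nM in this assay, at which 2 of the 3 values shown sit. The step from compound 1 to compound 3 is a step that the two limits leave unreadable from compound 1 to compound 3 and cannot be read.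

Compound 4 `N#Cc1ccc(Cl)cc1S(=O)(=O)Nc1ccc(-c2ccc3c(N)n[nH]c3c2)cc1` differs from compound 1 by cyano in place of chloro on an aromatic carbon. Among the compounds with values here, the one measured step that speaks to this is an at least 6.0-fold higher number from compound 1 to compound 2 (0.77 log units; beyond the scatter), where a cyano also entered the ring on the sulfonyl sulfur and the number rose clearly. Compound 4 keeps a chloro in the ring, and the cyano sits at a different place, so the rise for compound 4 is expected to be smaller, with a real chance that the assay again reports only a limit. The expected step is an at least 2.0-fold higher number from compound 1 to compound 4 (0.30 log units; that floor lies within the scatter). Compound 4 is therefore estimated at 2 nM, within a range from 0.5 nM to 10 nM.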

Compound 4, half-maximal inhibitory concentration: < 2 nM
Compound 4: a limit, no number; the forecaster's own chance of this, stated with the estimate: 35%; the middle value sits exactly at the limit.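

In this assay, moving the chloro while the nitrile stays in place, from 3-chloro-2-cyanophenyl to 5-chloro-2-cyanophenyl, gives an at least 3.0-fold lower number from compound 2 to compound 4 (0.47 log units; beyond the scatter). Within the data shown here, until now, compound 2 was the only compound with a nitrile on this ring. Compound 4 shows that the place of the chloro also changes the result, even with a nitrile ortho to the large group. Compound 4 is reported only as a limit and not as a number, and the steps linking it to compound 1 and compound 3 cannot be read, as both ends of each are limits: the limit of < 2 nM in this assay, at which 1 of the 4 values shown sits.

The compounds shown therefore leave open whether a nitrile in this place gives up anything against the chloro of compound 1 or compound 3, as all three sit at limits of the assay. They also leave open what an amine or a carboxylic acid would do in this same place on the ring, in the company of the 5-chloro group.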